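The compounds below may be only part of what the source reports. "The series", "measured", "known", "first", "only" and "open" are said of these compounds alone.

Measured compounds:
compound 1, `C=C(C)C(=O)N(Cc1cccc(Br)c1)C(=O)/C=C/c1cc(OC)c(OC)c(OC)c1`: > 10000 nM
compound 2, `C=C(C)C(=O)NC(=O)/C=C/c1cc(OC)c(OC)c(OC)c1`: 8200 nM

In a functional assay on PC-3 cells (Homo sapiens) for inhibition, read by WST assay, with a stated time of 48 h (on this read-out higher numbers stand for weaker inhibition of growth and lower numbers for stronger inhibition of growth), compound 1 gives > 10000 nM, which is a limit of the assay and not a number, (the limit of > 10000 nM in this assay, at which 1 of the 2 values shown sits). In this assay compound 2 gives 8200 nM. For the measured compounds named here, the one measured step, an at least 1.2-fold lower number from compound 1 to compound 2 (0.08 log units; that floor lies within the scatter), lies within the scatter. Compound 3, `C=C(C)C(=O)N(Cc1ccc(Br)cc1)C(=O)/C=C/c1cc(OC)c(OC)c(OC)c1`, differs from compound 1 by 4-bromophenyl in place of 3-bromophenyl on a saturated chain carbon bound to an amide-type nitrogen. Going by the values given here, no measured step concerns a change of this kind, so no step beyond the scatter is expected in this assay, and a limit again seems likely. For compound 3 the estimate is 12000 nM, with a range of 4000 nM to 40000 nM. The expected step is a step that the limit leaves unreadable from compound 1 to compound 3.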

Compound 3, concentration for 50% growth inhibition: > 10000 nM
Compound 3 was reported as a limit; the forecaster's own chance of this, stated with the estimate: 60%; the middle value is on the limit's open side.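

In this assay compound 3 gives > 10000 nM, again a limit and not a number: the limit of > 10000 nM in this assay, at which 2 of the 3 values shown sit.

The step from 3-bromobenzyl to 4-bromobenzyl cannot be read, and neither bromobenzyl group yields a number here. For 4-bromobenzyl in place of hydrogen on an amide-type nitrogen, only a floor is readable: an at least 1.2-fold higher number from compound 2 to compound 3 (0.08 log units; that floor lies within the scatter).

Going by these compounds, how far the number rises with either bromobenzyl group remains open. Also open, on these data alone, is whether a small group such as methyl, or a chain carrying an amine, on this nitrogen would give a readable value in this assay.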